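Bromo for Chloro in Two Cytotoxicity Pairs

A few compounds are considered here, and "the series" means these few. Any claim that something is new, unique, unknown or untested is made for them only; others in the source may bear on it.

Compound 1, `N#Cc1c(N)cccc1Sc1cccc(Cl)c1`: 53000 nM
Compound 2, `N#Cc1c(N)cccc1Sc1cccc(Br)c1`: 53000 nM
Compound 3, `N#Cc1c(N)cccc1S(=O)(=O)c1ccc(Cl)cc1`: > 5000 nM

All three compounds were tested in a functional assay on MT4 cells (Homo sapiens) for cytotoxicity; on this read-out lower numbers stand for stronger inhibition and higher numbers for weaker inhibition. Compound 1 and compound 2 share a core and differ by bromo in place of chloro on an aromatic carbon. That exchange gave no change at the digits printed from compound 1 to compound 2 (within the scatter), so the two values are treated as the same.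

For compound 3 this assay reports only a limit, > 5000 nM. That reading is the limit of > 5000 nM in this assay, at which 1 of the 3 values shown sits. How the core of compound 3 differs from the core of compound 1 is not broken down here.

Compound 4, `N#Cc1c(N)cccc1S(=O)(=O)c1ccc(Br)cc1`, has not yet been measured. It differs from compound 3 by bromo in place of chloro on an aromatic carbon. The group that leaves and the group that enters are the same as in the pair of compound 1 and compound 2, but the surroundings are not identical: in the first pair the halogen sits meta to a large group, in the second pair para to a large group, so this is the same kind of change rather than the same change.

The step from compound 3 to compound 4 is expected to be a step that the limit leaves unreadable from compound 3 to compound 4, an expectation that rests on no change at the digits printed from compound 1 to compound 2 (within the scatter) for the earlier pair. Compound 4 is estimated at 30000 nM, with a range from 5000 nM to 150000 nM, and it may well return only a limit in this assay, as compound 3 did.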

Compound 4, half-maximal inhibitory concentration: > 200000 nM
Compound 4 was reported as a limit (the forecaster's own chance of this, stated with the estimate: 70%); middle value at least 6.6-fold (0.82 log units) from the limit.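

In this assay, compound 3 is reported only as a limit, > 5000 nM. Compound 4 is likewise reported only as a limit, > 200000 nM. Neither limit is a number, so no step can be read between compound 3 and compound 4. The compounds shown leave open how large a change, if any, bromo in place of chloro brings in this assay when it sits para to a large group.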